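Chloro in place of hydrogen on a factor X series

The source may report more compounds than this note shows. Statements on the series, on what has been measured and on what is new or still open speak of the compounds shown alone.

Measured compounds:
Compound 1 `O=C1[C@@H](NS(=O)(=O)c2cc3ncccc3s2)CCN1Cc1cc2c[nH]ccc-2n1` — in an assay on isolated protein for inhibition of coagulation factor X (Oryctolagus cuniculus), tested at 1 uM (on this read-out lower numbers stand for less inhibition and higher numbers for more inhibition at the one concentration tested (going by the name of the read-out)), compound 1 gives 61%.
Compound 2 `Cc1c(S(=O)(=O)N[C@H]2CCN(Cc3cc4cc[nH]cc-4n3)C2=O)sc2ccc(Cl)cc12` — in this assay compound 2 gives 52%.

Compound 1 has the higher of the two numbers shown, but compound 2 sits within the usual scatter of it, so the two are best read as matching rather than as one being stronger. Compound 2 also differs from compound 1 in more than one place, so nothing can be drawn from that pair about any single change.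

Compound 3 `O=C1[C@@H](NS(=O)(=O)c2cc3nc(Cl)ccc3s2)CCN1Cc1cc2c[nH]ccc-2n1` is the next compound to be measured. It differs from compound 1 in a single way: chloro in place of hydrogen on an aromatic carbon. Among the measured compounds shown here, no pair of measured compounds shows what such a change does here, so the expectation rests only on compound 1 itself.

Compound 3 is expected to give a number close to compound 1, with no step beyond the scatter: the step from a number 1 percentage points higher from compound 1 to compound 3 (within the scatter) is estimated to be small. Compound 3 is therefore estimated at 62%, with a range from 42% to 80%.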

Compound 3, a percentage reported as inhibition, at one concentration (the size of the read-out at that concentration, not a potency): 58%
Compound 3: the middle estimate sits 4 percentage points above what was measured; the measured number falls inside the stated range.
By their numbers in this assay, from the lowest: compounds 2, 3 and 1 (each within the scatter of the next).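

In this assay, among the compounds shown here, chloro in place of hydrogen gives a number 3 percentage points lower from compound 1 to compound 3 (within the scatter), the first reading of a single change. On this aromatic carbon next to the ring nitrogen, one chlorine atom therefore leaves compound 3 matching compound 1 within the usual scatter, so the result gives no sign that the hydrogen here matters for the read-out at the one concentration tested. No measurement at hand speaks to the reason for this result.

Going by these compounds, what an amine, a methoxy group or a carboxylic acid would do at this same position stays open, as one chloro group cannot show whether other groups there would also leave the number unmoved. On these data alone, each number is also a percentage at one concentration rather than a potency, so a small real difference between compound 1 and compound 3 could stay hidden in the scatter, and the effect of chloro on other carbons of the core of compound 1 remains unknown.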